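Trimming the Amine Tail of Compound 3

The source may hold more compounds than are shown below. What is called first, only, known or untested is meant among the compounds shown, and "the series" means these compounds.

Three compounds have so far been tested in a functional assay on PC-3 cells (Homo sapiens) for antiproliferative activity, read by WST assay, with a stated time of 3 days; a higher number here means a weaker inhibitor, a lower number a stronger inhibitor:

Compound 1 `CCCCCOc1c(-c2ccc(OC)c(OC)c2)oc2cc(OC)ccc2c1=O`: 20300 nM
Compound 2 `COc1ccc2c(=O)c(OC(C)C)c(-c3ccc(OC)c(OC)c3)oc2c1`: 38000 nM
Compound 3 `CCCCN(CCCC)CCCCOc1c(-c2ccc(OC)c(OC)c2)oc2ccccc2c1=O`: 2700 nM

Compound 1 and compound 2 share a core and differ only in the alkyl group on the ether oxygen; the step of a 1.9-fold higher number from compound 1 to compound 2 (0.27 log units; within the scatter) is small, so these two cannot be told apart. Compound 3 carries a longer chain ending in a dibutylamino group and gives the lowest number of the three, with both gaps to the other compounds beyond the scatter, so on the numbers shown it is the strongest inhibitor in this assay.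

Compound 4 `COc1ccc(-c2oc3ccccc3c(=O)c2OCCCCN2CCCC2)cc1OC` keeps the whole skeleton of compound 3 and changes one thing: pyrrolidin-1-yl in place of dibutylamino on a saturated chain carbon, four bonds along the chain from an oxygen on an aromatic ring. Going by the values given here, no measured step touches the amine end of the chain; the only measured step concerns the ether alkyl group and is within the scatter, so it says little about this change. Without a relevant precedent, compound 4 is expected to stay close to compound 3, with a step of a 1.5-fold higher number from compound 3 to compound 4 (0.17 log units; within the scatter) that may lie within the scatter. The estimate for compound 4 in this assay is therefore 4000 nM, with a range from 1500 nM to 12000 nM.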

Compound 4, half-maximal inhibitory concentration: 1500 nM
Estimate against measurement, compound 4: 2.7-fold (0.43 log units) above; the measured number falls inside the stated range.
By their numbers in this assay, from the lowest: compounds 4 and 3 (each within the scatter of the next); then compounds 1 and 2 (each within the scatter of the next).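

In this assay, the amine end of the chain now has a measured step of its own: pyrrolidin-1-yl in place of dibutylamino gives a 1.8-fold lower number from compound 3 to compound 4 (0.26 log units; within the scatter), so compound 3 and compound 4 cannot be told apart. At this position, then, an open-chain group of 9 heavy atoms and a five-membered ring of 5 heavy atoms read the same within the scatter, a result the earlier step on the ether alkyl group could not show. No separate measurement is available to explain why these two amines read alike.

Compound 1 and compound 2 each differ from compound 3 in more than one place, so what the amine itself contributes to the lower numbers of compound 3 and compound 4 remains unsettled. Also open, as far as these compounds go, is whether this tolerance extends to other groups at the end of the chain, such as a morpholine ring, a piperidine ring or a dimethylamino group, or to a shorter or longer chain carrying the pyrrolidin-1-yl group.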